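Fused quinone series: widening the cyclic amine ring

The source may hold more compounds than are shown below. What is called first, only, known or untested is meant among the compounds shown, and "the series" means these compounds.

Measured in a functional assay on HeLa cells (Homo sapiens) for inhibition, read by sulforhodamine B assay; a higher number here means a weaker inhibitor, a lower number a stronger inhibitor:
- compound 1, `O=C1C=C(N2CCC2)C(=O)c2c1nc1n2[C@H]2OC[C@@H](O)[C@H]2OC1`: > 16000 nM, a limit of the assay
- compound 2, `O=C1C(N2CCC2)=CC(=O)c2c1nc1n2[C@H]2OC[C@@H](O)[C@H]2OC1`: > 16000 nM, a limit of the assay
- compound 3, `O=C1C(NC2CCCCC2)=CC(=O)c2c1nc1n2[C@H]2OC[C@@H](O)[C@H]2OC1`: > 16000 nM, a limit of the assay

Compound 1 stands only at a limit, and the two other values are limits as well; all three sit at the limit of > 16000 nM in this assay, at which 3 of the 3 values shown sit. Among the compounds with values here, the one single-point step recorded, a step that the two limits leave unreadable from compound 2 to compound 3, is therefore unreadable in size and direction.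

Compound 4, `O=C1C=C(N2CCCC2)C(=O)c2c1nc1n2[C@H]2OC[C@@H](O)[C@H]2OC1`, differs from compound 1 by pyrrolidin-1-yl in place of azetidin-1-yl on a double-bonded ring carbon. Within the data shown here, no measured step bears on this change, and nothing among the three compounds shows any value below the limit. The expected step is a step that the limit leaves unreadable from compound 1 to compound 4, which is to say none readable. Compound 4 is expected to report again only a limit, estimated at 25000 nM (range 8000 nM to 100000 nM).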

Compound 4, half-maximal inhibitory concentration: > 16000 nM
Compound 4 ended at the assay's limit (the forecaster's own chance of this, stated with the estimate: 80%); the middle value lies beyond the limit too.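

No step can be read between compound 1 and compound 4, since both stop at an assay limit: the limit of > 16000 nM in this assay, at which 4 of the 4 values shown sit.

The compounds shown leave open whether any amino group on the shared core gives a measurable value in this assay.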